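Adding a Fluoro Group to Compound 2

The source may report more compounds than this note shows. Statements on the series, on what has been measured and on what is new or still open speak of the compounds shown alone.

Of the compounds shown here, two built on a shared core have been measured so far. In a functional assay on MCF7 cells (Homo sapiens) for antiproliferative activity, with a stated time of 72 h (on this read-out lower numbers stand for stronger inhibition and higher numbers for weaker inhibition), compound 1 `C=C1C=CC(=O)[C@@H]2[C@H](Cc3ccc(F)c(F)c3)CC[C@H]12`, which has a fluorinated aromatic ring, gives 233 nM. Compound 2 `C=C1C=CC(=O)[C@@H]2[C@H](Cc3ccc(O)cc3)CC[C@H]12`, which has a hydroxy group on that ring, gives 33.8 nM. This is the lower of the two numbers, and the gap between them lies beyond the usual scatter, so compound 2 stands as the stronger inhibitor of the pair.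

Compound 3 `C=C1C=CC(=O)[C@@H]2[C@H](Cc3ccc(O)c(F)c3)CC[C@H]12` has not yet been measured. It differs from compound 2 by fluoro in place of hydrogen on an aromatic carbon, ortho to a hydroxy group and meta to a large group. Going by the values given here, no measured pair isolates this change, so any expectation is indirect. Compound 3 keeps the hydroxy group of compound 2 at 33.8 nM, and it shares ring fluorine with compound 1 at 233 nM, which has no hydroxy group. A small rise, probably not beyond the scatter, is expected in this assay, with an estimated change of a 1.3-fold higher number from compound 2 to compound 3 (0.12 log units; within the scatter). For compound 3 the expected value is 45 nM, with an estimated range from 17 nM to 120 nM.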

Compound 3, half-maximal inhibitory concentration: 147 nM
Beside the measured number, compound 3's estimate is 3.3-fold (0.51 log units) below it; the measured number lies above the stated range.
By their numbers in this assay, from the lowest: compound 2; then compounds 3 and 1 (each within the scatter of the next).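

In this assay, fluoro in place of hydrogen on an aromatic carbon, ortho to a hydroxy group and meta to a large group, proves not to be a silent change, since it brings a 4.3-fold higher number from compound 2 to compound 3 (0.64 log units; beyond the scatter). With fluoro at this place, hydroxy in place of fluoro on an aromatic carbon gives only a 1.6-fold lower number from compound 1 to compound 3 (0.20 log units; within the scatter), so in this fluorinated setting the exchange of that second ring substituent makes no difference beyond the scatter, and the hydroxy group alone does not secure a low number. No measurement at hand accounts for the rise on adding fluoro.

The compounds shown carry only hydrogen or fluoro at this carbon, so they leave open whether the rise is particular to fluoro or would also come with chloro, a methyl group or a methoxy group at the same place. They also leave open how an amine or a carboxylic acid in place of the hydroxy group would read alongside the fluoro, and whether the small step seen between hydroxy and fluoro there would hold.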